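From tert-Butyl to Methoxy on a Shared Core

The source may report more compounds than this note shows. Statements on the series, on what has been measured and on what is new or still open speak of the compounds shown alone.

Compound 1, `CN1CCC[C@@H]1Cn1nc(Cc2ccc(C(C)(C)C)cc2)c2ccccc2c1=O`: in an assay for binding affinity to Alpha-1B adrenergic receptor (Homo sapiens) (a lower number here means a stronger inhibitor, a higher number a weaker inhibitor), compound 1 gives > 1990 nM, which is a limit of the assay.
Compound 2, `CN1CCCC1CCn1nc(Cc2ccc(Cl)cc2)c2ccccc2c1=O`: compound 2 gives 316 nM.
Compound 3, `O=c1c2ccccc2c(Cc2ccc(Cl)cc2)nn1C[C@H]1CCCN1CCCCCc1ccc(OCCCN2CCCCCC2)cc1`: compound 3 gives 50.1 nM.

Compound 1 therefore stands only at the limit, as the limit of > 1990 nM in this assay, at which 1 of the 3 values shown sits, records; no number is known for it. Compound 4, `COc1ccc(Cc2nn(C[C@H]3CCCN3C)c(=O)c3ccccc23)cc1`, differs from compound 1 by methoxy in place of tert-butyl on an aromatic carbon. No two of the measured compounds differ in one place, so the size of such a change cannot be read from them; compound 2 and compound 3 carry a chloro group and other linkers. The step of an at least 2.2-fold lower number from compound 1 to compound 4 (0.34 log units; beyond the scatter) is expected to run toward stronger binding, beyond the scatter, since the tert-butyl compound sits at the limit. Compound 4 is estimated at 900 nM, in the range 200 nM to 4000 nM.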

Compound 4, inhibition constant: 158 nM
Compound 4: the middle estimate sits 5.7-fold (0.76 log units) above what was measured; measured number outside the range, below it.
By their numbers in this assay, from the lowest: compound 3; then compounds 4 and 2 (each within the scatter of the next). At a limit, above all of these: compound 1.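

In this assay, methoxy in place of tert-butyl on an aromatic carbon gives an at least 12-fold lower number from compound 1 to compound 4 (1.10 log units; beyond the scatter), the only step among these compounds that isolates this position. It shows that the group at this place, para to a large group, can change the number well beyond the scatter. Compound 1 stands at a limit, so the step has only a lower bound on its size: the limit of > 1990 nM in this assay, at which 1 of the 4 values shown sits.

As far as these compounds go, it remains open whether the change comes from losing tert-butyl or from adding methoxy. From the compounds shown here alone, how a hydroxyl, a fluoro group or an amine at this place would read in this assay also remains open.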